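The source may report more compounds than this note shows. Statements on the series, on what has been measured and on what is new or still open speak of the compounds shown alone.

Measured so far:
compound 1, `CCCNC(=O)c1ccc(Oc2nc(-c3c(C)noc3C)cnc2N)cc1`: 32100 nM
compound 2, `Cc1noc(C)c1-c1cnc(N)c(Oc2ccc(C(=O)Nc3ccccc3)cc2)n1`: 10500 nM

In a functional assay on HeLa cells (Homo sapiens) for inhibition, read by MTT assay, with a stated time of 72 h (a higher number here means a weaker inhibitor, a lower number a stronger inhibitor), compound 2 stands lowest of the two numbers shown; the only step, a 3.1-fold lower number from compound 1 to compound 2 (0.49 log units; beyond the scatter), came from phenyl in place of propyl on an amide-type nitrogen. Compound 3, `Cn1cc(-c2cnc(N)c(Oc3ccc(C(=O)Nc4ccccc4)cc3)n2)cn1`, differs from compound 2 by 1-methyl-1H-pyrazol-4-yl in place of 3,5-dimethyl-1,2-oxazol-4-yl on an aromatic carbon. For the measured compounds named here, no measured step touches that position, so the step from compound 1 to compound 2 gives no guide here, and nothing beyond the scatter is expected. The estimated step is no change at the digits printed from compound 2 to compound 3 (within the scatter). Compound 3 is expected near 10500 nM, within a wide range of 3000 nM to 36000 nM.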

Compound 3, half-maximal inhibitory concentration: 12300 nM
Compound 3: middle estimate off by 1.2-fold (0.07 log units), on the low side; the measured number falls inside the stated range.
By their numbers in this assay, from the lowest: compounds 2 and 3 (each within the scatter of the next); then compound 1.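

For the compounds shown here, this is the first change at the aromatic carbon para to an amino group, and in this assay it gives a 1.2-fold higher number from compound 2 to compound 3 (0.07 log units; within the scatter), so 1-methyl-1H-pyrazol-4-yl and 3,5-dimethyl-1,2-oxazol-4-yl cannot be told apart here. With the phenyl amide held constant, this position accepts either five-membered aromatic ring. No available evidence bears on this result. As far as these compounds go, whether a morpholine, a primary amine or a carboxylic acid at this carbon would give a similar number stays open. Also open, from the compounds shown here alone, is whether the same ring exchange would read alike on the propyl amide of compound 1.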